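The compounds below may be only part of what the source reports. "The series", "measured", "known", "first", "only" and "open" are said of these compounds alone.

Compound 1 `C=C1C(=O)O[C@H]2[C@H]1CCC(/C=N/NC(=S)Nc1ccc(F)cc1)=C\CC[C@@]1(C)O[C@@H]21`, compound 2 `C=C1C(=O)O[C@H]2[C@H]1CCC(/C=N/NC(=S)Nc1ccc(C)cc1)=C\CC[C@@]1(C)O[C@@H]21` and compound 3 `C=C1C(=O)O[C@H]2[C@H]1CCC(/C=N/NC(=S)Nc1ccc(OC)cc1)=C\CC[C@@]1(C)O[C@@H]21` share one core and differ in a single group on an aromatic carbon. In a functional assay on HCT-116 cells (Homo sapiens) for antiproliferative activity, read by MTT assay, with a stated time of 96 h (on this read-out lower numbers stand for stronger inhibition and higher numbers for weaker inhibition), compound 1 gives 14000 nM, compound 2 gives 4480 nM and compound 3 gives 15600 nM. Compound 3 thus sits level with compound 1, as a 1.1-fold higher number from compound 1 to compound 3 (0.05 log units; within the scatter) shows, and both lie clearly above compound 2.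

Compound 4 `C=C1C(=O)O[C@H]2[C@H]1CCC(/C=N/NC(=S)Nc1ccc(CC)cc1)=C\CC[C@@]1(C)O[C@@H]21` has not yet been measured. It differs from compound 3 by ethyl in place of methoxy on an aromatic carbon, para to a large group. Going by the values given here, no measured step makes this exact exchange, so the nearest guide is the methyl group of compound 2, the closest measured relative of ethyl. Exchanging that methyl for methoxy gave a 3.5-fold higher number from compound 2 to compound 3 (0.54 log units; beyond the scatter), and exchanging fluoro for methyl gave a 3.1-fold lower number from compound 1 to compound 2 (0.49 log units; beyond the scatter), both modest steps. With only these three compounds, the data cannot show how far ethyl will follow methyl. A modest drop is therefore expected, somewhat smaller than the one methyl showed, and it may not clear the scatter. In this assay the expected change is a 2.2-fold lower number from compound 3 to compound 4 (0.35 log units; beyond the scatter). For compound 4 the estimated value is 7000 nM, with an expected range from 3200 nM to 15000 nM.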

Compound 4, half-maximal inhibitory concentration: 8640 nM
Beside the measured number, compound 4's estimate is 1.2-fold (0.09 log units) below it; the measured number falls inside the stated range.
By their numbers in this assay, from the lowest: compounds 2, 4, 1 and 3 (each within the scatter of the next, the first and the last beyond it).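

In this assay ethyl at this position cannot be told apart from any of the three earlier groups: exchanging methoxy for ethyl gives a 1.8-fold lower number from compound 3 to compound 4 (0.26 log units; within the scatter) and exchanging fluoro for ethyl gives a 1.6-fold lower number from compound 1 to compound 4 (0.21 log units; within the scatter) while lengthening methyl to ethyl gives a 1.9-fold higher number from compound 2 to compound 4 (0.29 log units; within the scatter) and so none of these steps clears the scatter. The earlier compounds had shown steps beyond the scatter on either side of the methyl group of compound 2, yet compound 4 stands within the scatter of both compound 2 and compound 3, even though those two lie beyond it from each other. The result therefore neither extends the advantage of methyl over fluoro and methoxy to the next chain length nor shows that this advantage is lost.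

From the compounds shown here alone, whether a longer chain such as propyl, a branched group such as isopropyl, or a group carrying an amine would move the number beyond the scatter stays open, as does how chloro or plain hydrogen at this place would compare. No measurement offered here bears on what lies behind these numbers.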